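This account rests on a few compounds, and the source may have more. Where it says the series, first, only, none or still open, it means among the compounds named here.

Of the compounds shown here, three of a shared core have been measured in a functional assay on PC-3 cells (Homo sapiens) for antiproliferative activity, read by MTT assay, tested at 1 uM; on this read-out higher numbers stand for a stronger effect at the one concentration tested and lower numbers for a weaker effect. For the measured compounds named here, compound 1 `COc1cc(C(=O)N/N=C/c2ccc(F)c(F)c2)cc(OC)c1OC` gives 35.1%, and compound 3 `COc1cc(C(=O)N/N=C/c2ccc(F)cc2)cc(OC)c1OC` gives 76%; the step of a number 40.9 percentage points higher from compound 1 to compound 3 (beyond the scatter) is the only one between two compounds that differ in one place. Compound 2 `COc1cc(C2=NN(C(C)=O)C(c3c(Cl)cccc3Cl)O2)cc(OC)c1OC` gives 5.1%, the lowest of the three numbers, sitting well under compound 1 and far under compound 3.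

Compound 4 `COc1cc(C2=NN(C(C)=O)C(c3ccc(F)c(F)c3)O2)cc(OC)c1OC` is not yet measured. It differs from compound 2 in one place: 3,4-difluorophenyl in place of 2,6-dichlorophenyl on a saturated ring carbon. Going by the values given here, no measured step swaps these two groups on this part of the core, so nothing directly bears on it; the step from compound 1 to compound 3 concerns a different exchange on another core. Compound 1 does carry the entering 3,4-difluorophenyl on its own core and gives only a middling number, while the core of compound 2 starts from the lowest value. A small rise is therefore expected, though not one clearly beyond the scatter: the step of a number 9.9 percentage points higher from compound 2 to compound 4 (within the scatter) is the estimate. Compound 4 is estimated at 15%, within 0% to 40%.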

Compound 4, a percentage reported as inhibition, at one concentration (the size of the read-out at that concentration, not a potency): 35.5%
Compound 4: the middle estimate sits 20.5 percentage points below what was measured, within the range that was stated.
By their numbers in this assay, from the lowest: compound 2; then compounds 1 and 4 (each within the scatter of the next); then compound 3.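

In this assay, placing 3,4-difluorophenyl instead of 2,6-dichlorophenyl on the saturated ring carbon gives a number 30.4 percentage points higher from compound 2 to compound 4 (beyond the scatter), so the read-out on this core clearly depends on which of these two groups the carbon carries. The two groups have the same heavy-atom count and neither has a hydrogen-bond donor or acceptor, so those counts do not separate them; what differs is the halogen and the pattern in which it is attached. Nothing at hand gives a reason for this rise.

Still open, from the compounds shown here alone, is whether the higher number comes from losing the chlorine atoms, gaining the fluorine atoms or changing their pattern, which a plain phenyl on this carbon could help separate. Also open, going by these compounds, is how a non-aromatic group, such as cyclohexyl or a chain bearing an amine, would behave here.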